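This account rests on a few compounds, and the source may have more. Where it says the series, first, only, none or still open, it means among the compounds named here.

Compound 1 `COc1nc2ccc(Br)cc2cc1C(c1ccccc1)n1cc(-c2ccc(Br)cc2)nn1` gives 13.4% in an ADME assay on SK-OV-3 cells (Homo sapiens) for cytotoxicity, read by sulforhodamine B assay, with a stated time of 48 h, tested at 10 uM; on this read-out lower numbers stand for less inhibition and higher numbers for more inhibition at the one concentration tested (going by the name of the read-out).
Compound 2 `CCCCCCCc1cn(C(c2ccccc2)c2cc3cc(Br)ccc3nc2OC)nn1` gives 10.5% in this assay.
Compound 3 `COc1nc2ccc(Br)cc2cc1C(c1ccccc1)n1cc(-c2ccc(OC(F)(F)F)cc2)nn1` gives 14.8% in this assay.

Compound 3 carries the highest of the three numbers, yet both a number 1.4 percentage points higher from compound 1 to compound 3 (within the scatter) and a number 4.3 percentage points higher from compound 2 to compound 3 (within the scatter) lie within the scatter, so no ordering among the three can be claimed. Compound 4 `COc1nc2ccc(Br)cc2cc1C(c1ccccc1)n1cc(-c2ccc(F)cc2)nn1` differs from compound 3 in one place: fluoro in place of trifluoromethoxy on an aromatic carbon. Among the compounds with values here, the only measured step at the same position, a number 1.4 percentage points higher from compound 1 to compound 3 (within the scatter), stayed within the scatter, and even the larger exchange a number 2.9 percentage points lower from compound 1 to compound 2 (within the scatter) did so. No step beyond the scatter is therefore expected in this assay. Compound 4 is estimated at 13%, with a range from 4% to 22%. The expected step is a number 1.8 percentage points lower from compound 3 to compound 4 (within the scatter).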

Compound 4, a percentage reported as inhibition, at one concentration (the size of the read-out at that concentration, not a potency): 14.3%
Beside the measured number, compound 4's estimate is 1.3 percentage points below it; low and high end bracket the measured number.
By their numbers in this assay, from the lowest: compounds 2, 1, 4 and 3 (each within the scatter of the next).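

In this assay, fluoro reads the same within the scatter as trifluoromethoxy (a number 0.5 percentage points lower from compound 3 to compound 4 (within the scatter)) and as bromo (a number 0.9 percentage points higher from compound 1 to compound 4 (within the scatter)), so all three groups on this six-membered aromatic ring are now indistinguishable at this position. Exchanging heptyl for the whole 4-fluorophenyl group also stays within the scatter (a number 3.8 percentage points higher from compound 2 to compound 4 (within the scatter)). No measured evidence bears on these readings. On these data alone, whether an amine or a carboxylic acid on this ring would move the number beyond the scatter remains open. So does the effect of any change elsewhere on the shared core.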